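Swapping a nitrile for a methoxy group on the phenyl ring

The source may hold more compounds than are shown below. What is called first, only, known or untested is meant among the compounds shown, and "the series" means these compounds.

Two close relatives share one core and differ only at a single spot on a phenyl ring. Compound 1 `COC(=O)C1=C(C)N=C(C)/C(=C(/O)OC)C1c1cccc(N/C(=N/CCNC2CCN(c3ccccc3)CC2)NC#N)c1` carries a hydrogen there, and in an assay on SK-N-MC cells for inhibition of Neuropeptide Y receptor type 1 (Homo sapiens) (on this read-out lower numbers stand for stronger inhibition and higher numbers for weaker inhibition), compound 1 gives 10 nM. Compound 2 `COC(=O)C1=C(C)N=C(C)/C(=C(/O)OC)C1c1cccc(N/C(=N/CCNC2CCN(c3ccccc3C#N)CC2)NC#N)c1` carries a cyano group there, and in this assay compound 2 gives 3 nM. Among the measured compounds shown here, that single change produced a 3.3-fold lower number from compound 1 to compound 2 (0.52 log units; beyond the scatter), so compound 2 stands as the lower of the two numbers measured so far. Compound 3 `COC(=O)C1=C(C)N=C(C)/C(=C(/O)OC)C1c1cccc(N/C(=N/CCNC2CCN(c3ccccc3OC)CC2)NC#N)c1` is not yet measured; it differs from compound 2 by methoxy in place of cyano on an aromatic carbon. For the measured compounds named here, no measured step shows how a methoxy group compares with a cyano group at this spot; the only guide is the step in this assay from compound 1 to compound 2, which shows that removing the cyano group costs about that much. A number between those of compound 1 and compound 2 is therefore expected, a step of a 2.0-fold higher number from compound 2 to compound 3 (0.30 log units; within the scatter). For compound 3 in this assay the estimate is 6 nM, within 2 nM to 20 nM.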

Compound 3, half-maximal inhibitory concentration: 4 nM
For compound 3 the middle estimate is 1.5-fold (0.18 log units) above the measured one; the measured number falls inside the stated range.
By their numbers in this assay, from the lowest: compounds 2 and 3 (each within the scatter of the next); then compound 1.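

Exchanging the cyano group for a methoxy group on this aromatic carbon, ortho to a large group, gives a 1.3-fold higher number from compound 2 to compound 3 (0.12 log units; within the scatter) in this assay, so the two groups cannot be told apart on this read-out. Measured against hydrogen at the same spot, the methoxy group gives a 2.5-fold lower number from compound 1 to compound 3 (0.40 log units; beyond the scatter), which shows that the gain seen with the cyano group is not unique to a nitrile: both of these two groups give a lower number than hydrogen. Nothing measured here explains why these two different groups give such similar results.

Still open, going by these compounds, is how other groups at this spot, such as an amine, a carboxylic acid or a longer chain like ethoxy, would compare. Also open, on these data alone, is whether a cyano or methoxy group would give similar numbers on another carbon of this ring.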